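The source may report more compounds than this note shows. Statements on the series, on what has been measured and on what is new or still open speak of the compounds shown alone.

In a functional assay on the whole organism with Mus musculus as the target (on this read-out higher numbers stand for an effect only at larger amounts of compound and lower numbers for an effect already at smaller amounts), compound 1 `CCn1c(=O)[nH]c2c(ncn2C2O[C@H](CO)[C@@H](O)[C@H]2O)c1=N` is reported only as a limit, > 100 mg/kg. Compound 2 `Cn1c(=O)[nH]c2c(ncn2C2O[C@H](CI)[C@@H](O)[C@H]2O)c1=N` is likewise reported only as a limit, > 100 mg/kg. Together they give (the limit of > 100 mg/kg in this assay, at which 2 of the 2 values shown sit), so the position of compound 2 is bounded on one side and no number fixes it. The account now turns to compound 3 `C[C@H]1OC(n2cnc3c(=N)n(C)c(=O)[nH]c32)[C@H](O)[C@@H]1O`, which has not yet been measured in this assay. Its structure departs from that of compound 2 in one place: hydrogen in place of iodo on a saturated chain carbon bound to a saturated ring carbon. Hydrogen stands in place of iodo on a saturated chain carbon bound to a saturated ring carbon, so that iodomethyl becomes methyl. For the measured compounds named here, no measured step shows what such a change does in this assay. The expectation therefore rests on compound 2, whose value of > 100 mg/kg is a limit. The expected change, a step that the limit leaves unreadable from compound 2 to compound 3, is no shift beyond the scatter in either direction. A further limit is the likeliest report. Should a number appear, compound 3 is estimated at 150 mg/kg, with an expected range from 60 mg/kg to 350 mg/kg.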

Compound 3, dose for half-maximal effect: > 100 mg/kg
Compound 3 gave a limit, no number (the forecaster's own chance of this, stated with the estimate: 80%); the middle value is on the limit's open side.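

Compound 3, like compound 2, is reported in this assay only as a limit, so no step can be read between compound 2 and compound 3: the limit of > 100 mg/kg in this assay, at which 3 of the 3 values shown sit. The compounds shown leave open what replacing iodomethyl with methyl does in this assay and at what dose, if any, an effect would be given a number.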